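Capping a ring nitrogen of compound 2

This account rests on a few compounds, and the source may have more. Where it says the series, first, only, none or still open, it means among the compounds named here.

Compound 1 `Cc1c2c(n3c1CCCNC[C@H](C)Nc1cc-3ccc1C(N)=O)CC(C)(C)CC2=O`: 366 nM
Compound 2 `Cc1c2c(n3c1CCNC[C@@H](C)[C@H](C)Nc1cc-3ccc1C(N)=O)CC(C)(C)CC2=O`: 40 nM

Both numbers come from a functional assay on U-87MG ATCC cells (Homo sapiens) for antiproliferative activity (a lower number here means a stronger inhibitor, a higher number a weaker inhibitor), and are half-maximal inhibitory concentrations. Of the two, compound 2 at 40 nM has the lower number, and its gap to compound 1 at 366 nM lies beyond the usual scatter of repeated measurements. Compound 2 is therefore the stronger inhibitor of this pair.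

Compound 3 `Cc1c2c(n3c1CCN(C(=O)C(C)(C)N)C[C@@H](C)[C@H](C)Nc1cc-3ccc1C(N)=O)CC(C)(C)CC2=O` alters compound 2 in one place ((1-amino-1-methylethyl)carbonyl in place of hydrogen on an amine nitrogen in a ring) and carries (1-amino-1-methylethyl)carbonyl in place of hydrogen on an amine nitrogen in a ring. Among the measured compounds shown here, no measured pair shows what a change at this nitrogen does, so any expectation here is loose. Compound 1 at 366 nM shows only that much higher numbers do occur among these compounds. A move toward weaker inhibition is expected, modestly beyond the scatter, and the estimated change is a 3.0-fold higher number from compound 2 to compound 3 (0.48 log units; beyond the scatter) with wide uncertainty. Compound 3 is estimated at 120 nM in this assay with 30 nM and 450 nM as the expected ends of the range.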

Compound 3, half-maximal inhibitory concentration: 39 nM
For compound 3 the middle estimate is 3.1-fold (0.49 log units) above the measured one; low and high end bracket the measured number.
By their numbers in this assay, from the lowest: compounds 3 and 2 (each within the scatter of the next); then compound 1.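

Adding a sizeable group to this ring nitrogen need not cost activity in this assay: with (1-amino-1-methylethyl)carbonyl, 6 heavy atoms in all, in place of hydrogen on the amine nitrogen, the result is a 1.0-fold lower number from compound 2 to compound 3 (0.01 log units; within the scatter). The two compounds therefore cannot be told apart in this measurement, which makes this the first sign that the hydrogen on this nitrogen is not needed to keep activity at this level, and that the position can carry an amide-forming group with its own amine. Nothing available here explains why the number holds steady when the group is added.

With only one group at this nitrogen, the compounds shown cannot say whether the amine inside the new group contributes anything, a question that a plain acetyl group, which has the carbonyl but no amine, could help to settle. From the compounds shown here alone, it also remains open how much more this nitrogen would accept, for example a longer chain ending in an amine, or a carboxylic acid in place of that amine.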